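The compounds below may be only part of what the source reports. "The series", "measured", "known", "first", "only" and "open" are said of these compounds alone.

Working notes on the series in a functional assay on A549 cells (Homo sapiens) for antiproliferative activity, read by CCK-8 assay, with a stated time of 48 h; a lower number here means a stronger inhibitor, a higher number a weaker inhibitor.

Three amides on a shared core have been measured. Compound 1 `O=C(NCc1ccccc1)c1cc(Oc2ccc(/C=C/c3ccccn3)cc2)ccn1` gives 18800 nM in this assay. Compound 2 `COc1ccc(CNC(=O)c2cc(Oc3ccc(/C=C/c4ccccn4)cc3)ccn2)cc1` gives 63600 nM, and compound 3 `O=C(NC1CC1)c1cc(Oc2ccc(/C=C/c3ccccn3)cc2)ccn1` gives 17300 nM. Compound 3 carries the lowest number of the three, but its gap to compound 1 is within the scatter, so no order between those two is claimed; only compound 2 stands apart, with a 3.7-fold lower number from compound 2 to compound 3 (0.57 log units; beyond the scatter) and a 3.4-fold higher number from compound 1 to compound 2 (0.53 log units; beyond the scatter).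

The next step goes from compound 3 to compound 4 `O=C(c1cc(Oc2ccc(/C=C/c3ccccn3)cc2)ccn1)N1CCCC1`: pyrrolidin-1-yl in place of cyclopropylamino on a carbonyl carbon. The measured steps that touch the same position are a 1.1-fold lower number from compound 1 to compound 3 (0.04 log units; within the scatter), which was flat, and the modest 3.7-fold lower number from compound 2 to compound 3 (0.57 log units; beyond the scatter). Within the data shown here, neither covers an exchange of this kind, so the amide position is known to tolerate different substituents but the change to pyrrolidin-1-yl itself has no precedent here. The expectation is therefore a step of a 1.5-fold higher number from compound 3 to compound 4 (0.18 log units; within the scatter), close to the scatter, with weakening considered somewhat more likely than strengthening. Compound 4 is estimated at 26000 nM, within 8000 nM to 85000 nM.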

Compound 4, half-maximal inhibitory concentration: 15600 nM
The estimate for compound 4 lay 1.7-fold (0.22 log units) above the measured number; low and high end bracket the measured number.
By their numbers in this assay, from the lowest: compounds 4, 3 and 1 (each within the scatter of the next); then compound 2.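

In this assay, the first tertiary amide in the series, with no amide hydrogen left on the carbonyl group, shows that this hydrogen is not needed to stay level with the secondary amides: pyrrolidin-1-yl in place of cyclopropylamino gives a 1.1-fold lower number from compound 3 to compound 4 (0.04 log units; within the scatter), and pyrrolidin-1-yl in place of benzylamino gives a 1.2-fold lower number from compound 1 to compound 4 (0.08 log units; within the scatter). Among the four compounds, only compound 2 goes against this flat picture, and the exchange of its (4-methoxybenzyl)amino group gives a 4.1-fold lower number from compound 2 to compound 4 (0.61 log units; beyond the scatter). No measurement is at hand that would explain why these amides sit so close together or why compound 2 stands apart.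

Going by these compounds, whether a morpholine or piperidine ring, or an open dimethylamino group, on the same carbonyl carbon would stay level with compound 4 remains open. Also open, on these data alone, is whether a carboxylic acid or a primary amine on the amide substituent would move the number beyond the scatter.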